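The compounds below may be only part of what the source reports. "The series", "measured", "known", "first", "only" and "open" are said of these compounds alone.

Cell toxicity is a basic safety check for any new compound, and here it is measured by an ADME assay on HEK-293T cells (Homo sapiens) for cytotoxicity, read by CCK-8 assay, with a stated time of 24 h; on this read-out lower numbers stand for higher toxicity in this test and higher numbers for lower toxicity in this test. For the measured compounds named here, in this test compound 1 `COc1ccccc1CNC(=O)CSc1c[nH]c2c(-c3ccccc3)cccc12` gives 95500 nM, which is the only exact number available. Compound 2 `COc1ccccc1CNC(=O)CSc1c[nH]c2cccc(Br)c12` is reported only as a limit, > 100000 nM. Compound 1 therefore cannot be ranked against a second exact value, and its figure is best read simply as a high number, which on this scale means low toxicity.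

Compound 3 `COc1ccccc1CNC(=O)CSc1c[nH]c2c(Br)cccc12` keeps the core of compound 1 and changes one group bromo in place of phenyl on an aromatic carbon. Going by the values given here, no measured pair shows what this kind of swap does, so the expectation is cautious. Compound 1, at 95500 nM, already shows little toxicity in this assay, and no strong effect is expected from the swap. The expected step is a 1.0-fold higher number from compound 1 to compound 3 (0.02 log units; within the scatter), which is no larger than the usual scatter. Compound 3 is estimated at 100000 nM, within an expected range of 55000 nM to 180000 nM.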

Compound 3, half-maximal cytotoxic concentration: 72400 nM
Compound 3: the middle estimate sits 1.4-fold (0.14 log units) above what was measured; the measured number falls inside the stated range.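

Replacing phenyl with bromo on this aromatic carbon gives a 1.3-fold lower number from compound 1 to compound 3 (0.12 log units; within the scatter). For the compounds shown here, this is the first measured change at this position, and it shows that a whole aromatic ring can give way to a single bromine atom without a change that can be told apart from ordinary repeat-to-repeat variation in this assay, so compound 1 and compound 3 must be treated as equal here. Compound 2 is reported only as a limit and not as a number, and the exact results for compound 1 and compound 3 lie not far from it, so all three compounds sit in the same high region of the scale: the limit of > 100000 nM in this assay, at which 1 of the 3 values shown sits.

The compounds shown leave open whether a different kind of group on this carbon, such as an amine, a carboxylic acid or a longer alkyl chain, would also keep the number in this high region. With a single step at this position, no trend can be drawn, and only a compound with a clearly lower number could show that the group placed here matters for toxicity in these cells.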